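The source may hold more compounds than are shown below. What is called first, only, known or untested is meant among the compounds shown, and "the series" means these compounds.

Series of acylated aryltriazenes. Compound 1 `O=C(c1cccc(F)c1)N(/N=N/c1ccc([N+](=O)[O-])cc1Cl)c1ccc([N+](=O)[O-])cc1Cl` gives 2500 nM in a functional assay on HeLa cells (Homo sapiens) for cytotoxicity, read by MTT assay, with a stated time of 72 h; on this read-out lower numbers stand for stronger inhibition and higher numbers for weaker inhibition. Compound 2 `O=C(c1ccccc1C(F)(F)F)N(/N=N/c1ccc([N+](=O)[O-])cc1C(F)(F)F)c1ccc([N+](=O)[O-])cc1C(F)(F)F` gives 5350 nM in this assay, the higher of the two numbers, a gap to compound 1 beyond the scatter; as the two differ in more than one place, the gap is not assigned to any single change. Compound 3 `O=C(c1ccc(F)cc1)N(/N=N/c1ccc([N+](=O)[O-])cc1C(F)(F)F)c1ccc([N+](=O)[O-])cc1C(F)(F)F` carries 4-fluorophenyl in place of 2-(trifluoromethyl)phenyl on a carbonyl carbon. Among the measured compounds shown here, no directly comparable step has been measured. A modest step toward a lower number, within or near the scatter, is expected, as a 1.5-fold lower number from compound 2 to compound 3 (0.18 log units; within the scatter). For compound 3 the expected value is 3500 nM, with a range from 1500 nM to 8000 nM.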

Compound 3, half-maximal inhibitory concentration: 1000 nM
Compound 3: middle estimate off by 3.5-fold (0.54 log units), on the high side; measured number below the stated range.
By their numbers in this assay, from the lowest: compound 3; then compound 1; then compound 2.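

Among the compounds shown here, on a carbonyl carbon, 4-fluorophenyl in place of 2-(trifluoromethyl)phenyl gives a 5.4-fold lower number from compound 2 to compound 3 (0.73 log units; beyond the scatter) in this assay, the first single-place step. The number therefore responds to the group on this carbonyl carbon while the rest of the molecule stays fixed. No measurement on hand explains the step.

The change swaps the substituent and its ring position together, and the compounds shown do not separate the two. On these data alone, how an unsubstituted phenyl or an aminophenyl group would read at this carbonyl carbon also remains open.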